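Cyclohexyl in Place of Benzyl on the Amide Nitrogen

The source may hold more compounds than are shown below. What is called first, only, known or untested is meant among the compounds shown, and "the series" means these compounds.

Three compounds share one core and differ only in the group on the amide-type nitrogen. Compound 1 `CNC(=O)c1cc(Oc2ccc(/C=C/c3ccccn3)cc2)ccn1` carries a methyl there, and in a functional assay on A549 cells (Homo sapiens) for antiproliferative activity, read by CCK-8 assay, with a stated time of 48 h (on this read-out higher numbers stand for weaker inhibition and lower numbers for stronger inhibition), compound 1 gives 17400 nM. Compound 2 `O=C(Nc1ccccc1)c1cc(Oc2ccc(/C=C/c3ccccn3)cc2)ccn1` carries a phenyl, and compound 2 gives 19100 nM. Compound 3 `O=C(NCc1ccccc1)c1cc(Oc2ccc(/C=C/c3ccccn3)cc2)ccn1` carries a benzyl, and compound 3 gives 18800 nM. None of these changes moved the number: a 1.1-fold higher number from compound 1 to compound 2 (0.04 log units; within the scatter), a 1.1-fold higher number from compound 1 to compound 3 (0.03 log units; within the scatter) and a 1.0-fold lower number from compound 2 to compound 3 (0.01 log units; within the scatter). Compound 3 thus holds the second highest of the three numbers, but its gaps to compound 2 and to compound 1 both lie within the scatter, so no order among the three can be read.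

Among the measured compounds shown here, compound 4 `O=C(NC1CCCCC1)c1cc(Oc2ccc(/C=C/c3ccccn3)cc2)ccn1` is not yet measured. cyclohexyl in place of benzyl on an amide-type nitrogen The nearest measured step is the one from compound 2 to compound 3, where a benzyl replaced a phenyl on the same nitrogen and nothing changed, and the steps from compound 1 likewise stayed flat. A saturated ring in place of an aromatic one is a somewhat different kind of change, yet nothing here points to a direction. Compound 4 is therefore expected to sit close to compound 3, with a 1.0-fold lower number from compound 3 to compound 4 (0.02 log units; within the scatter) staying within the scatter, at an estimated 18000 nM within a range of 9000 nM to 40000 nM.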

Compound 4, half-maximal inhibitory concentration: 12500 nM
Compound 4: middle estimate off by 1.4-fold (0.16 log units), on the high side; low and high end bracket the measured number.
By their numbers in this assay, from the lowest: compounds 4, 1, 3 and 2 (each within the scatter of the next).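

Cyclohexyl brings a non-aromatic ring onto the amide-type nitrogen for the first time, and in this assay this new kind of ring still gives no step that can be read as a real difference: cyclohexyl in place of benzyl gives (a 1.5-fold lower number from compound 3 to compound 4 (0.18 log units; within the scatter)), cyclohexyl in place of phenyl gives (a 1.5-fold lower number from compound 2 to compound 4 (0.18 log units; within the scatter)) and cyclohexyl in place of methyl gives (a 1.4-fold lower number from compound 1 to compound 4 (0.14 log units; within the scatter)). The flat picture at this position therefore no longer rests on methyl and aromatic rings alone, and it now also covers a saturated ring of carbon only. No measurement shown here offers an explanation for this flat result.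

From the compounds shown here alone, all four groups consist of carbon only and have no hydrogen-bond donors or acceptors, so it remains open whether an amine, a carboxylic acid or a longer chain on this nitrogen would give a step beyond the scatter. Going by these compounds, it also remains open whether the same insensitivity would hold if the amide hydrogen were replaced by a second methyl group.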